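Carbonyl substituent swaps on the shared core

The source may hold more compounds than are shown below. What is called first, only, known or untested is meant among the compounds shown, and "the series" means these compounds.

Measured so far:
- compound 1 `COC(=O)/C=C/c1ccncc1-c1ccc2ccccc2c1`: 4710 nM
- compound 2 `O=C(/C=C/c1ccncc1-c1ccc2ccccc2c1)N1CCOCC1`: 8980 nM

The series is read in a functional assay on MDA-MB-231 cells (Homo sapiens) for inhibition, read by sulforhodamine B assay, with a stated time of 72 h; on this read-out higher numbers stand for weaker inhibition of growth and lower numbers for stronger inhibition of growth. Among the compounds with values here, only two numbers exist so far, and compound 2 at 8980 nM stands within the scatter of compound 1 at 4710 nM. The next compound is compound 3 `CN(C)C(=O)/C=C/c1ccncc1-c1ccc2ccccc2c1`, with dimethylamino in place of morpholin-4-yl on a carbonyl carbon. Within the data shown here, one measured step bears on this change, since it falls at the same carbonyl carbon: a 1.9-fold higher number from compound 1 to compound 2 (0.28 log units; within the scatter), with morpholin-4-yl in place of methoxy. That step stayed within the scatter, so a swap at this carbon is not expected to move the number much in this assay. The expected change is a 1.2-fold lower number from compound 2 to compound 3 (0.08 log units; within the scatter), with none beyond the scatter anticipated. For compound 3 the estimate is 7500 nM, with an expected range of 3500 nM to 16000 nM.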

Compound 3, concentration for 50% growth inhibition: 7990 nM
Compound 3: the middle estimate sits 1.1-fold (0.03 log units) below what was measured, and the stated range covers the measured number.
By their numbers in this assay, from the lowest: compounds 1, 3 and 2 (each within the scatter of the next).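

At the carbonyl carbon, dimethylamino in place of morpholin-4-yl gives a 1.1-fold lower number from compound 2 to compound 3 (0.05 log units; within the scatter) in this assay and shows that, among these compounds, the six-membered ring of morpholin-4-yl is not required to keep the number in this range. Dimethylamino in place of methoxy gives a 1.7-fold higher number from compound 1 to compound 3 (0.23 log units; within the scatter) on the same read-out, so methoxy, morpholin-4-yl and dimethylamino at this carbon now all stand within the scatter of one another, with no compound going against that reading among the three. No measurement here offers an explanation for this flat reading.

Going by these compounds, whether a carboxylic acid, a primary amide or a longer alkyl chain on this carbonyl carbon would also stay within the scatter remains open. Also open, on these data alone, is whether a change elsewhere on the shared core would move the number further than any swap at this carbon has.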